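Sulfonamide series: pyrimidine replacement of the substituted pyridine

A few compounds are considered here, and "the series" means these few. Any claim that something is new, unique, unknown or untested is made for them only; others in the source may bear on it.

Measured compounds in a functional assay on isolated protein for antagonist activity at C-C chemokine receptor type 9 (Homo sapiens), read by calcium flux, with a stated time of 10 min; on this read-out lower numbers stand for stronger inhibition and higher numbers for weaker inhibition:
- compound 1, `CC(C)(C)c1ccc(S(=O)(=O)Nc2ccc(Cl)cc2-c2ncccc2N)cc1`, gives 95 nM
- compound 2, `CC(C)(C)c1ccc(S(=O)(=O)Nc2ccc(Cl)cc2-c2nccc(C(N)=O)c2O)cc1`, gives 52 nM

Compound 2 has the lowest of the two numbers in this assay; its nearest neighbour is compound 1, and the step of a 1.8-fold lower number from compound 1 to compound 2 (0.26 log units; within the scatter) lies within the scatter, so the two compounds are not separated on this read-out.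

Compound 3 is `CC(C)(C)c1ccc(S(=O)(=O)Nc2ccc(Cl)cc2-c2ncncc2N)cc1`. Relative to compound 2 the change is a group of 7 heavy atoms (4 carbon, 3 nitrogen; one six-membered aromatic ring with 2 hetero atoms) in place of a group of 10 heavy atoms (6 carbon, 2 nitrogen, 2 oxygen; one six-membered aromatic ring with 1 hetero atom), on an aromatic carbon. For the measured compounds named here, the only measured step that bears on this position is a 1.8-fold lower number from compound 1 to compound 2 (0.26 log units; within the scatter), which exchanged one ring-bearing group for another at the same aromatic carbon without a difference beyond the scatter. Going by the values given here, no measured step covers the entry of a ring with two hetero atoms, so the expectation rests on that single exchange alone. The expected outcome is a step no larger than the scatter, estimated as a 1.7-fold higher number from compound 2 to compound 3 (0.24 log units; within the scatter).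

For compound 3 the estimate in this assay is 90 nM, with a range from 30 nM to 270 nM.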

Compound 3, half-maximal inhibitory concentration: 3.2 nM
Compound 3: middle estimate off by 28-fold (1.45 log units), on the high side; measured number below the stated range.
By their numbers in this assay, from the lowest: compound 3; then compounds 2 and 1 (each within the scatter of the next).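

In this assay, this place on the aromatic carbon, ortho to a large group, turns out to be sensitive to the ring it carries: a 16-fold lower number from compound 2 to compound 3 (1.21 log units; beyond the scatter) and a 30-fold lower number from compound 1 to compound 3 (1.47 log units; beyond the scatter) both lie beyond the scatter, whereas a 1.8-fold lower number from compound 1 to compound 2 (0.26 log units; within the scatter) stayed within it. The comparison of compound 1 with compound 3 is the more telling one, since both groups have 7 heavy atoms and the entering group differs in having a six-membered aromatic ring with 2 hetero atoms instead of 1 hetero atom, so a large step arises here with no change in heavy-atom count. Nothing on hand explains the size of this step.

The compounds shown leave open whether the ring with 2 hetero atoms carries the gain by itself or only together with the amine on that ring, a question that a methyl or methoxy group in its place would address. Also open, going by these compounds, is whether the carboxamide and hydroxyl pair of compound 2 would be tolerated on the ring of compound 3.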